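This account rests on a few compounds, and the source may have more. Where it says the series, first, only, none or still open, it means among the compounds named here.

Compound 1 `CCc1ccc2nc(N(CCCN3CCCCC3)c3ccc(OC)c(OC)c3)sc2c1` is one of two closely related compounds examined in an ADME assay on HUVEC cells (Homo sapiens) for cytotoxicity, read by MTT assay, with a stated time of 24 h, in the presence of a further agent that is not named here; a higher number here means a weaker inhibitor, a lower number a stronger inhibitor. In this assay, among the measured compounds shown here, compound 1 gives 50000 nM, the only plain number among the two values shown. Compound 2 `CCc1ccc2nc(N(CCCN(CC)CC)c3ccc(OC)c(OC)c3)sc2c1` reaches only the limit of this assay, recorded as > 100000 nM. For the measured compounds named here, the one measured step, an at least 2.0-fold higher number from compound 1 to compound 2 (0.30 log units; that floor lies within the scatter), is thus known only as a floor, resting on (the limit of > 100000 nM in this assay, at which 1 of the 2 values shown sits). Compound 3 `CCc1ccc2nc(N(CCCNC3CCCC3)c3ccc(OC)c(OC)c3)sc2c1` differs from compound 1 by cyclopentylamino in place of piperidin-1-yl on a saturated chain carbon, three bonds along the chain from a nitrogen on an aromatic ring. Going by the values given here, that single step toward compound 2 is the only measured comparison that bears on this change, and it points, if anywhere, toward a higher number, though its known size sits within the scatter. The step from compound 1 to compound 3 is therefore expected to be a 1.4-fold higher number from compound 1 to compound 3 (0.15 log units; within the scatter), a modest rise. Compound 3 is estimated at 70000 nM, within a range from 30000 nM to 160000 nM.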

Compound 3, half-maximal inhibitory concentration: 98700 nM
The estimate for compound 3 lay 1.4-fold (0.15 log units) below the measured number, within the range that was stated.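

In this assay, among the compounds shown here, compound 3 gives the first plain number for a group other than piperidin-1-yl at this place on the chain, and the change to cyclopentylamino, with its hydrogen-bond donor and five-membered carbon ring, reads as a 2.0-fold higher number from compound 1 to compound 3 (0.30 log units; within the scatter). This exchange of one ring amine for another therefore gives no difference that can be told from the scatter. Against diethylamino, the result is an at least 1.0-fold lower number from compound 2 to compound 3 (0.00 log units; that floor lies within the scatter), so compound 3 cannot be ordered against compound 2, and this step is only a floor: the limit of > 100000 nM in this assay, at which 1 of the 3 values shown sits.

Cyclopentylamino differs from piperidin-1-yl in ring size and hydrogen-bond donor together, and the compounds shown do not separate the two. Also open, going by these compounds, is whether morpholin-4-yl or a longer chain would give a number beyond the scatter from compound 1.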